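Moving a Hydroxyl on the Hydrazone Aryl Group

The source may report more compounds than this note shows. Statements on the series, on what has been measured and on what is new or still open speak of the compounds shown alone.

Three compounds share one core and differ only in the aryl group on a carbon with a double bond to nitrogen. Compound 1 `CN(C)CCn1cnnc1-c1cc(Oc2ccc(NC(=O)N/N=C/c3c[nH]c4ccccc34)cc2F)ccn1` gives 790 nM in a functional assay on MKN-45 cells (Homo sapiens) for cytotoxicity, read by MTT assay, with a stated time of 72 h; on this read-out lower numbers stand for stronger inhibition and higher numbers for weaker inhibition. Compound 2 `COc1ccc(/C=N/NC(=O)Nc2ccc(Oc3ccnc(-c4nncn4CCN(C)C)c3)c(F)c2)c(OC)c1OC` gives 2020 nM in this assay, and compound 3 `CN(C)CCn1cnnc1-c1cc(Oc2ccc(NC(=O)N/N=C/c3ccc(O)c(O)c3)cc2F)ccn1` gives 3240 nM. Compound 3 thus stands highest of the three numbers, nearest to compound 2 and furthest from compound 1. The measured steps were a 2.6-fold higher number from compound 1 to compound 2 (0.41 log units; beyond the scatter), a 4.1-fold higher number from compound 1 to compound 3 (0.61 log units; beyond the scatter) and a 1.6-fold higher number from compound 2 to compound 3 (0.21 log units; within the scatter).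

Compound 4 `CN(C)CCn1cnnc1-c1cc(Oc2ccc(NC(=O)N/N=C/c3ccc(O)cc3O)cc2F)ccn1` is not yet measured. It differs from compound 3 by 2,4-dihydroxyphenyl in place of 3,4-dihydroxyphenyl on a carbon with a double bond to nitrogen. Going by the values given here, the two steps leaving 1H-indol-3-yl were modest but beyond the scatter, whereas the step between the two oxygen-bearing groups lay within it, and no measured step moves a hydroxyl from one place on the ring to another. The step of a 1.1-fold lower number from compound 3 to compound 4 (0.03 log units; within the scatter) is therefore expected to stay within the scatter. Compound 4 is estimated at 3000 nM, in a range from 1400 nM to 6500 nM.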

Compound 4, half-maximal inhibitory concentration: 2860 nM
Compound 4: middle estimate off by 1.0-fold (0.02 log units), on the high side, within the range that was stated.
By their numbers in this assay, from the lowest: compound 1; then compounds 2, 4 and 3 (each within the scatter of the next).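

Moving a hydroxyl around the ring, a change no earlier step covered, gives a 1.1-fold lower number from compound 3 to compound 4 (0.05 log units; within the scatter) in this assay, so 2,4-dihydroxyphenyl and 3,4-dihydroxyphenyl cannot be told apart on this read-out at this position. The step of a 1.4-fold higher number from compound 2 to compound 4 (0.15 log units; within the scatter) also stays within the scatter, which places both dihydroxyphenyl compounds and the 2,3,4-trimethoxyphenyl compound together in one cluster of numbers. Only 1H-indol-3-yl stands apart from that cluster, with a 3.6-fold higher number from compound 1 to compound 4 (0.56 log units; beyond the scatter) showing the same separation once more.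

As far as these compounds go, whether an amine or a carboxylic acid on this aryl ring would move the number beyond the scatter remains open. Nothing available explains why the hydroxyl's place leaves the number unresolved or why 1H-indol-3-yl stands apart.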